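Swapping a Cyclopropyl for a Methoxyphenyl on a Lactam Nitrogen

The compounds below may be only part of what the source reports. "The series", "measured", "known", "first", "only" and "open" are said of these compounds alone.

Measured so far:
compound 1 `O=C1COc2ccc(-c3cccc(NS(=O)(=O)c4ccc(F)cc4)c3)cc2N1C1CC1` — > 40000 nM
compound 2 `O=C1COc2ccc(-c3cnc4ccccc4c3)cc2N1c1ccc(Cl)cc1` — > 40000 nM

Compound 1 was tested in a functional assay on HeLa cells (Homo sapiens) for antiproliferative activity, read by MTT assay, with a stated time of 72 h; on this read-out higher numbers stand for weaker inhibition and lower numbers for stronger inhibition. Compound 1 reaches only the limit of the measurement, > 40000 nM, so no number is known for it. Compound 2 also reaches only a limit, > 40000 nM. Both values sit at the limit of > 40000 nM in this assay, at which 2 of the 2 values shown sit, so nothing places compound 1 above or below the other compound.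

Compound 3 `COc1cccc(N2C(=O)COc3ccc(-c4cccc(NS(=O)(=O)c5ccc(F)cc5)c4)cc32)c1` is not yet measured. It differs from compound 1 at the amide-type nitrogen in a ring of the shared core: 3-methoxyphenyl in place of cyclopropyl on an amide-type nitrogen in a ring. For the measured compounds named here, no step between two measured compounds exists here, so the size of this change is not known from data. The expected step of a number no higher from compound 1 to compound 3 (the limit leaves the size open) is taken as none beyond the scatter. Compound 3 is estimated at 40000 nM, with a range from 8000 nM to 200000 nM.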

Compound 3, half-maximal inhibitory concentration: > 40000 nM
Compound 3 ended at the assay's limit; the forecaster's own chance of this, stated with the estimate: 70%; the middle value lies on the limit itself.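

Compound 1 and compound 3 both stand only at a limit, not at a number, so no step from one to the other can be read: the limit of > 40000 nM in this assay, at which 3 of the 3 values shown sit.

The compounds shown leave open how 3-methoxyphenyl and cyclopropyl on the amide-type nitrogen compare, and what actual value lies behind each limit.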